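The source may report more compounds than this note shows. Statements on the series, on what has been measured and on what is new or still open speak of the compounds shown alone.

Series notes. Compound 1 `C=C1C(=O)[C@]23C[C@@]1(O)CC[C@H]2c1ccc(OS(=O)(=O)c2ccc(C)cc2)c(C)c1[C@@H]3Cn1cc(-c2ccc(Br)cc2)nn1` is the point of departure. In a functional assay on SW480 cells (Homo sapiens) for cytotoxicity, read by MTT assay, with a stated time of 4 days (a lower number here means a stronger inhibitor, a higher number a weaker inhibitor), compound 1 gives 1590 nM. Its two measured companions differ from it only on the aromatic ring carried by the triazole: compound 2 `C=C1C(=O)[C@]23C[C@@]1(O)CC[C@H]2c1ccc(OS(=O)(=O)c2ccc(C)cc2)c(C)c1[C@@H]3Cn1cc(-c2ccc(Cl)cc2)nn1` gives 2390 nM in this assay, and compound 3 `C=C1C(=O)[C@]23C[C@@]1(O)CC[C@H]2c1ccc(OS(=O)(=O)c2ccc(C)cc2)c(C)c1[C@@H]3Cn1cc(-c2ccc(C)cc2)nn1` gives 1460 nM. Among these three numbers compound 1 stands second highest; the step of a 1.5-fold higher number from compound 1 to compound 2 (0.18 log units; within the scatter) and the step of a 1.1-fold lower number from compound 1 to compound 3 (0.04 log units; within the scatter) both stay within the scatter, as does a 1.6-fold lower number from compound 2 to compound 3 (0.21 log units; within the scatter), so the three compounds cannot be told apart on these data.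

Compound 4 `C=C1C(=O)[C@]23C[C@@]1(O)CC[C@H]2c1ccc(O)c(C)c1[C@@H]3Cn1cc(-c2ccc(Br)cc2)nn1` is not yet measured. It differs from compound 1 at another place altogether: hydrogen in place of (4-methylphenyl)sulfonyl on an oxygen on an aromatic ring. None of the three recorded steps touches this oxygen; each of them exchanges a group on the aromatic ring attached to the triazole, and none of them reaches beyond the scatter. Within the data shown here, no measured step therefore bears on the change from compound 1 to compound 4, and the data leave its direction open. The expectation for compound 4 is a number close to that of compound 1, carried by a wide range, expressed as the step of a 1.0-fold higher number from compound 1 to compound 4 (0.00 log units; within the scatter). Compound 4 is thus estimated at 1600 nM in this assay, with a range from 500 nM to 5000 nM.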

Compound 4, half-maximal inhibitory concentration: 310 nM
Compound 4: the middle estimate sits 5.2-fold (0.71 log units) above what was measured; the measured number lies below the stated range.
By their numbers in this assay, from the lowest: compound 4; then compounds 3, 1 and 2 (each within the scatter of the next).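

Among these compounds, the oxygen on the aromatic ring is the first place where a single change moves the number in this assay beyond the scatter: hydrogen in place of (4-methylphenyl)sulfonyl gives a modest step (a 5.1-fold lower number from compound 1 to compound 4 (0.71 log units; beyond the scatter)), whereas the exchanges on the aromatic ring attached to the triazole left compound 1, compound 2 and compound 3 indistinguishable. The sulfonyl group is therefore not required for activity in this assay, since compound 4 retains cytotoxicity with a hydroxy group at this place and with the core of compound 1 otherwise unchanged. Nothing at hand accounts for the size or direction of this step.

The compounds shown leave open whether the shift depends on the free hydroxy itself or would also appear with a small group on the same oxygen, such as a methyl ether or an acetyl ester, or with a larger one, such as a benzenesulfonyl group without the methyl. They also leave open whether the same exchange would produce a comparable step with chloro or methyl in place of bromo on the aromatic ring attached to the triazole.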